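Two Quinoxaline Sulfones and a Shift of the Amino Group

This account rests on a few compounds, and the source may have more. Where it says the series, first, only, none or still open, it means among the compounds named here.

The set comprises four compounds built on one shared core, a quinoxaline carrying an arylsulfonyl group and an anilino group. Compound 1, `COc1ccc(S(=O)(=O)c2nc3ccccc3nc2Nc2ccc(N)cc2)cc1`, and compound 2, `COc1ccc(S(=O)(=O)c2nc3ccccc3nc2Nc2cccc(N)c2)cc1`, differ only in the anilino part: the change is 3-aminophenyl in place of 4-aminophenyl on a nitrogen on an aromatic ring. In a functional assay on A549 cells (Homo sapiens) for cytotoxicity, read by MTT assay, with a stated time of 72 h (a higher number here means a weaker inhibitor, a lower number a stronger inhibitor), compound 1 gives 2990 nM, while compound 2 gives 340 nM, so the change brings an 8.8-fold lower number from compound 1 to compound 2 (0.94 log units; beyond the scatter).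

Compound 3, `Nc1ccc(Nc2nc3ccccc3nc2S(=O)(=O)c2ccc(F)cc2)cc1`, shares the 4-aminophenyl group of compound 1 but differs from it in the sulfonyl part, where (fluoro in place of methoxy on an aromatic carbon). In this assay compound 3 gives 12700 nM, which is a 4.2-fold higher number from compound 1 to compound 3 (0.63 log units; beyond the scatter) and the highest number of the three measured compounds.

Compound 4, `Nc1cccc(Nc2nc3ccccc3nc2S(=O)(=O)c2ccc(F)cc2)c1`, has not yet been measured. It stands to compound 3 as compound 2 stands to compound 1: the difference is 3-aminophenyl in place of 4-aminophenyl on a nitrogen on an aromatic ring, and the place described for both changes is the same, so this is the same change made on the core of compound 3 instead of the core of compound 1. Among the measured compounds shown here, only one measured example of this change exists, the pair of compound 1 and compound 2, so no breadth of behaviour can be claimed. Resting on that one step, compound 4 is expected to show a 7.1-fold lower number from compound 3 to compound 4 (0.85 log units; beyond the scatter) relative to compound 3, a step of roughly the size seen from compound 1 to compound 2, with some allowance for the different core. Compound 4 is therefore estimated at 1800 nM, within a range from 600 nM to 6000 nM.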

Compound 4, half-maximal inhibitory concentration: 6840 nM
Estimate against measurement, compound 4: 3.8-fold (0.58 log units) below, outside the stated range (above it).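

On the core of compound 3, the same shift to 3-aminophenyl in place of 4-aminophenyl gives a 1.9-fold lower number from compound 3 to compound 4 (0.27 log units; within the scatter) in this assay, so the step seen on the core of compound 1 did not carry over at its earlier size: the same change on two cores in this assay, an 8.8-fold lower number (0.94 log units; beyond the scatter) from compound 1 to compound 2 and a 1.9-fold lower number (0.27 log units; within the scatter) from compound 3 to compound 4, 4.7-fold (0.68 log units) apart, beyond the scatter of two such steps Read the other way, fluoro in place of methoxy gives a 20-fold higher number from compound 2 to compound 4 (1.30 log units; beyond the scatter), so that change also depends on the partner it is made with, and the two comparisons are one square of four compounds seen from its two sides: the same change on two cores in this assay, a 4.2-fold higher number (0.63 log units; beyond the scatter) from compound 1 to compound 3 and a 20-fold higher number (1.30 log units; beyond the scatter) from compound 2 to compound 4, 4.7-fold (0.68 log units) apart, beyond the scatter of two such steps This shows that, in these four compounds, the effect of the amino group's place and the effect of the group on the sulfonyl part do not simply add up, but it does not show why, and two cores cannot tell how the shift would behave on a third.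

As far as these compounds go, it remains open whether a chloro or methyl group in place of fluoro or methoxy would give a step of the size seen with methoxy or of the size seen with fluoro. The same holds for a hydroxy or dimethylamino group in place of the amino group on the anilino part.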